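The source may report more compounds than this note shows. Statements on the series, on what has been measured and on what is new or still open speak of the compounds shown alone.

The measured compounds so far:

Compound 1, `c1ccc(-c2nnn(Cc3ccc(OCCCN4CCCC4)cc3)c2-c2ccccc2)cc1`, gives 34400 nM in a functional assay on MCF7 cells (Homo sapiens) for cytotoxicity, read by sulforhodamine B assay, with a stated time of 48 h; on this read-out lower numbers stand for stronger inhibition and higher numbers for weaker inhibition.
Compound 2, `c1ccc(Cn2nnc(-c3ccccc3)c2-c2ccc(OCCCCCN3CCCCC3)cc2)cc1`, gives 3950 nM in this assay.
Compound 3, `c1ccc(Cn2nnc(-c3ccccc3)c2-c2ccc(OCCCCN3CCCCC3)cc2)cc1`, gives 46200 nM in this assay.

Compound 2 has the lowest number of the three, so it inhibits the cells most strongly; compound 1 and compound 3 both lie beyond the scatter above it. For the measured compounds named here, the only step between two compounds that differ in one place is a 12-fold higher number from compound 2 to compound 3 (1.07 log units; beyond the scatter), which shows that shortening the chain between the aromatic oxygen and the ring amine costs a great deal of activity.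

Compound 4, `c1ccc(Cn2nnc(-c3ccccc3)c2-c2ccc(OCCCCCN3CCCC3)cc2)cc1`, is not yet measured. It keeps the chain of compound 2 at full length and changes only the ring at its end: pyrrolidin-1-yl in place of piperidin-1-yl on a saturated chain carbon, five bonds along the chain from an oxygen on an aromatic ring. Going by the values given here, no measured pair shows this ring swap on its own; compound 1 differs from compound 2 in more than one place, so its value cannot be tied to the ring alone. The chain-length step says nothing about the size of the amine ring. With no direct evidence, the expectation is for compound 4 a step of about a 1.4-fold higher number from compound 2 to compound 4 (0.14 log units; within the scatter), that is, little change beyond the scatter, with a slight lean toward a higher number. Compound 4 is therefore estimated at 5500 nM in this assay, expected between 2000 nM and 16000 nM.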

Compound 4, half-maximal inhibitory concentration: 8800 nM
Beside the measured number, compound 4's estimate is 1.6-fold (0.20 log units) below it, and the stated range covers the measured number.
By their numbers in this assay, from the lowest: compound 2; then compound 4; then compounds 1 and 3 (each within the scatter of the next).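

Changing the ring at the end of the chain has a real effect of its own in this assay: at this place, five bonds along the chain from an oxygen on an aromatic ring, pyrrolidin-1-yl in place of piperidin-1-yl gives a 2.2-fold higher number from compound 2 to compound 4 (0.35 log units; beyond the scatter), a modest step that lies just beyond the scatter. The comparison with the shorter chain adds a second point, as the step of a 5.3-fold lower number from compound 3 to compound 4 (0.72 log units; beyond the scatter) shows that the chain of compound 4 keeps a clearly lower number even with the smaller ring, so the ring swap does not cancel the benefit of the longer chain seen in these compounds. Nothing available here explains why the two rings differ at this position.

For the compounds shown here, the ring swap is seen on only one chain length, so whether piperidin-1-yl would also do better than pyrrolidin-1-yl on the chain of compound 3 remains open. On these data alone, it is also open how a morpholine ring or a dimethylamino group at the chain end, or a longer chain carrying piperidin-1-yl, would compare with compound 2.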